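From Phenethyl to 4-Fluorophenyl: Expected Permeability of Compound 4

This account rests on a few compounds, and the source may have more. Where it says the series, first, only, none or still open, it means among the compounds named here.

Of the compounds shown here, three built on a shared core have been measured in an ADME assay for permeability, using PAMPA, with a stated time of 30 min, at pH 7.4; on this read-out lower numbers stand for lower permeability and higher numbers for higher permeability. Compound 1 `COc1ccc(F)cc1CNCCCNc1ccnc2cc(Cc3cc(C)cc(C)c3)ccc12` gives 23 10^-6 cm/s. Compound 3 `COc1ccc(F)cc1CNCCCNc1ccnc2cc(CCc3ccccc3)ccc12` gives 23 10^-6 cm/s, and the step of no change at the digits printed from compound 1 to compound 3 (within the scatter) shows that this exchange on a saturated chain carbon left the number where it was. Compound 2 `Fc1ccc(Oc2ccc3c(NCCCNCc4ccco4)ccnc3c2)cc1` gives 317 10^-6 cm/s, the highest of the three and the furthest from compound 3, while compound 3 stands level with compound 1 at the digits shown, the two of them together lowest.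

Going by the values given here, compound 4 `COc1ccc(F)cc1CNCCCNc1ccnc2cc(-c3ccc(F)cc3)ccc12` has not yet been measured. 4-fluorophenyl in place of phenethyl on an aromatic carbon The only measured step, no change at the digits printed from compound 1 to compound 3 (within the scatter), swapped one group for another on a saturated chain carbon and did not move the number; it does not bear directly on a change that places a ring straight onto an aromatic carbon of the core. Among the compounds with values here, compound 2 differs from compound 3 in more than one place, so its two values give no single step. Compound 4 is therefore expected to show a step of a 1.1-fold higher number from compound 3 to compound 4 (0.04 log units; within the scatter) that stays within the scatter. For compound 4 in this assay the estimate is 25 10^-6 cm/s, with a range from 8 10^-6 cm/s to 70 10^-6 cm/s.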

Compound 4, apparent permeability: 237 10^-6 cm/s
Compound 4: middle estimate off by 9.5-fold (0.98 log units), on the low side; measured number above the stated range.
By their numbers in this assay, from the lowest: compounds 1 and 3 (each within the scatter of the next); then compounds 4 and 2 (each within the scatter of the next).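

In this assay, putting 4-fluorophenyl in place of phenethyl on this aromatic carbon gives a 10-fold higher number from compound 3 to compound 4 (1.01 log units; beyond the scatter), and putting it in place of 3,5-dimethylbenzyl gives a 10-fold higher number from compound 1 to compound 4 (1.01 log units; beyond the scatter). The earlier step, no change at the digits printed from compound 1 to compound 3 (within the scatter), had suggested that the number did not respond to what this part of the shared core carries, but that step only exchanged one ring held off the core by a saturated chain for another. Among compounds 1, 3 and 4, the number moves only when the ring sits directly on the aromatic carbon with no saturated chain, although nothing shown explains why the number rises.

The compounds shown leave open whether the step belongs to the fluorine or to the direct attachment of the ring, a question that a plain phenyl on the same carbon would help to separate. They also leave open how a ring bearing an amine or a carboxylic acid at this place, or a longer chain than phenethyl, would read in this assay.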